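From compound 3 to compound 4: one added methyl

The source may report more compounds than this note shows. Statements on the series, on what has been measured and on what is new or still open speak of the compounds shown alone.

In a functional assay on HepG2 cells (Homo sapiens) for cytotoxicity, with a stated time of 72 h (on this read-out lower numbers stand for an effect already at smaller amounts and higher numbers for an effect only at larger amounts of compound), compound 1 (`COc1ccc(/C=C/[C@@](C)(/C=C/c2ccc(O)cc2)CCC=C(C)C)cc1`) gives > 52000 nM as a limit of the assay and not as a number. Compound 2 (`CCOc1ccc(/C=C/[C@@](C)(/C=C/c2ccc(O)cc2)CCC=C(C)C)cc1`) gives > 52000 nM here, again only a limit. Compound 3 (`CC(C)=CCC[C@@](C)(/C=C/c1ccccc1)/C=C/c1ccc(O)cc1`) gives > 52000 nM here, also only a limit, so its position is known only as a bound. Within the data shown here, the series so far offers the limit of > 52000 nM in this assay, at which 3 of the 3 values shown sit, and no number.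

Compound 4 (`CC(C)=CCC[C@@](C)(/C=C/c1ccc(C)cc1)/C=C/c1ccc(O)cc1`) carries methyl in place of hydrogen on an aromatic carbon, para to a large group (methyl in place of hydrogen on an aromatic carbon), which reads as phenyl to 4-methylphenyl.

Among the measured compounds shown here, three measured steps bear on this change. Two are exchanges on an aromatic carbon, hydrogen for methoxy (a step that the two limits leave unreadable from compound 1 to compound 3) and hydrogen for ethoxy (a step that the two limits leave unreadable from compound 2 to compound 3). The third adds methyl on the saturated chain carbon bound to the oxygen (a step that the two limits leave unreadable from compound 1 to compound 2). None of the three has a readable size, so they fix no direction. In this assay no step beyond the scatter is therefore expected, and the expected step is small (a step that the limit leaves unreadable from compound 3 to compound 4). For compound 4 the estimated value is 60000 nM with an expected range from 25000 nM to 120000 nM and a strong chance that the outcome will be only a limit.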

Compound 4, half-maximal effective concentration: > 52000 nM
Compound 4 was reported as a limit; the forecaster's own chance of this, stated with the estimate: 75%; the middle value does not contradict the limit.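

No new step can be read among compound 1, compound 2, compound 3 and compound 4, because each result is only a limit and not a number: the limit of > 52000 nM in this assay, at which 4 of the 4 values shown sit.

The compounds shown leave open the size and direction of each exchange among hydrogen, methyl, methoxy and ethoxy on the aromatic carbon, and the concentration at which any of the four would show an effect.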